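Extending an ortho alkyl chain on an aryl sulfonamide urea

This account rests on a few compounds, and the source may have more. Where it says the series, first, only, none or still open, it means among the compounds named here.

Compound 3 `CCNC(=O)Nc1ccc(S(=O)(=O)Nc2ccccc2CC)cc1` belongs to a small set of aryl sulfonamide ureas that were tested in a functional assay on M21 cells (Homo sapiens) for cytotoxicity, read by sulforhodamine B assay, with a stated time of 48 h; a lower number here means a stronger inhibitor, a higher number a weaker inhibitor. In this assay compound 3 gives 90000 nM, the highest of the two numbers reported. Compound 1 `CCCc1ccccc1NS(=O)(=O)c1ccc(NC(=O)NCCCCl)cc1`, which carries a longer chain on both ends of the shared core, gives 38000 nM in this assay. Compound 2 `CCNC(=O)Nc1ccc(S(=O)(=O)Nc2ccccc2C)cc1` reaches only the limit (the limit of > 200000 nM in this assay, at which 1 of the 3 values shown sits), so its reading of > 200000 nM in this assay is a limit rather than a number.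

Compound 4 `CCCc1ccccc1NS(=O)(=O)c1ccc(NC(=O)NCC)cc1` differs from compound 3 by methyl in place of hydrogen on a saturated chain carbon, two bonds along the chain from an aromatic carbon, which reads as ethyl to propyl when cut one bond further out. Among the measured compounds shown here, the only measured step of the same kind is an at least 2.2-fold lower number from compound 2 to compound 3 (0.34 log units; beyond the scatter), the change from methyl to ethyl at the same position. That step points towards a lower number as the chain grows, and compound 1, which already carries the propyl chain, sits below compound 3 in this assay.

On that basis compound 4 is expected to show a modest lowering, a 2.3-fold lower number from compound 3 to compound 4 (0.35 log units; beyond the scatter), and its estimated value in this assay is 40000 nM, with a likely range from 15000 nM to 110000 nM.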

Compound 4, half-maximal inhibitory concentration: 41000 nM
Compound 4: middle estimate off by 1.0-fold (0.01 log units), on the low side; low and high end bracket the measured number.
By their numbers in this assay, from the lowest: compounds 1 and 4 (each within the scatter of the next); then compound 3. At a limit, above all of these: compound 2.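

Lengthening the chain a second time, from ethyl to propyl, lowers the number again in this assay: a 2.2-fold lower number from compound 3 to compound 4 (0.34 log units; beyond the scatter), so the trend seen from methyl to ethyl does not stop at ethyl. Across the whole change from methyl to propyl the result is an at least 4.8-fold lower number from compound 2 to compound 4 (0.68 log units; beyond the scatter), and that size is only a bound, as compound 2 is a limit and not a number: the limit of > 200000 nM in this assay, at which 1 of the 4 values shown sits. The earlier compounds shown here also could not separate the two ends of compound 1, and here, with propyl in place on both compounds, hydrogen in place of chloromethyl on a saturated chain carbon, two bonds along the chain from an amide-type nitrogen, gives a 1.1-fold higher number from compound 1 to compound 4 (0.03 log units; within the scatter), a step within the scatter.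

On these data alone, whether the trend carries on to a butyl or longer chain, or reverses there, stays open, as does the effect of a branched isopropyl group or of an amine or carboxylic acid at the end of the propyl chain. Whether these steps hold outside this assay also remains open, since the compounds shown give no other read-out.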